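The compounds below may be only part of what the source reports. "The series", "measured", "known", "first", "only" and "open" are said of these compounds alone.

Measured in an ADME assay on liver for metabolic stability, with Liver microsome (Homo sapiens) as the target, using microsomes and NADPH, with a stated time of 30 min, tested at 0.5 uM; on this read-out lower numbers stand for slow clearance and higher numbers for fast clearance:

Compound 1 `O=c1[nH]ccn1CCOc1nn(-c2ccccc2F)c2ccc(F)cc12`: 200 mL/min/kg
Compound 2 `O=C1NCCN1CCOc1nn(-c2ccccc2F)c2ccc(F)cc12`: 183 mL/min/kg

Among the measured compounds shown here, compound 2 stands among fast-clearing numbers, and it cannot be told apart from the only other measured compound. For the measured compounds named here, the one measured step is a 1.1-fold lower number from compound 1 to compound 2 (0.04 log units; within the scatter).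

Compound 3 `O=C1NCCN1CCOc1nn(-c2ccc(F)cc2F)c2ccc(F)cc12` keeps everything in compound 2 except for one change: fluoro in place of hydrogen on an aromatic carbon. Put simply, this is fluoro in place of hydrogen on an aromatic carbon, so 2-fluorophenyl becomes 2,4-difluorophenyl.

Going by the values given here, no measured pair tests this change. Among the compounds with values here, the single step available, a 1.1-fold lower number from compound 1 to compound 2 (0.04 log units; within the scatter), alters the ring on the saturated chain, a different part of the molecule, so it bears on the new fluoro only indirectly. It shows that one structural edit can leave this assay almost untouched, but it cannot show the direction of this one. With so little evidence, no shift beyond the scatter is expected, and the estimated step is a 1.1-fold lower number from compound 2 to compound 3 (0.06 log units; within the scatter).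

The expected value for compound 3 is 160 mL/min/kg, within an estimated range from 95 mL/min/kg to 230 mL/min/kg.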

Compound 3, clearance: 150 mL/min/kg
Compound 3: middle estimate off by 1.1-fold (0.03 log units), on the high side; the measured number falls inside the stated range.
By their numbers in this assay, from the lowest: compounds 3, 2 and 1 (each within the scatter of the next).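

In this assay, putting fluoro in place of hydrogen on the aromatic carbon para to a large group, which turns 2-fluorophenyl into 2,4-difluorophenyl, gives a 1.2-fold lower number from compound 2 to compound 3 (0.09 log units; within the scatter). Among the compounds shown here, the earlier compounds differed only in the ring on the saturated chain, so this is the first reading at this position, and it shows that the added fluoro leaves no difference that can be told from the ordinary spread of repeated measurements. All three compounds therefore remain among fast-clearing numbers, and nothing measured here offers an explanation for this result.

The compounds shown leave open whether a different group on this same aromatic carbon, such as methoxy, trifluoromethyl or an amine, would shift the number beyond the scatter. They also leave open whether a change elsewhere, such as a carboxylic acid in place of the ring on the saturated chain, or a longer chain leading to that ring, would bring the clearance clearly below these values.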